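The source may report more compounds than this note shows. Statements on the series, on what has been measured and on what is new or still open speak of the compounds shown alone.

Compound 1 `CCCC(Oc1ccc(-n2cc(C#N)cn2)cc1)c1ccc(C(=O)NCCC(=O)O)cc1` gives the highest number of the three measured compounds in an assay on cells for displacement of a labelled ligand from Glucagon receptor (Homo sapiens), in the presence of a further agent that is not named here; a lower number here means a stronger inhibitor, a higher number a weaker inhibitor: compound 1 gives 4100 nM. Compound 2 `CCCC(Oc1ccc(-n2cc(C(F)(F)F)cn2)nc1)c1ccc(C(=O)NCCC(=O)O)cc1` gives 230 nM and compound 3 `CCCC(Nc1cnc(-n2cc(C(F)(F)F)cn2)nc1)c1ccc(C(=O)NCCC(=O)O)cc1` gives 100 nM, both well below compound 1 and beyond the usual scatter, but each differs from compound 1 in more than one place, so no single change can be read from them. Compound 4 `CCCC(Oc1ccc(-n2cc(C)cn2)cc1)c1ccc(C(=O)NCCC(=O)O)cc1` differs from compound 1 in one place: methyl in place of cyano on an aromatic carbon. Among the measured compounds shown here, with no comparable step among the measured compounds, the change is expected to shift the number by little, if at all, beyond the scatter, giving an estimated step of a 1.2-fold lower number from compound 1 to compound 4 (0.07 log units; within the scatter). Compound 4 is therefore expected to give about 3500 nM, within a range of 1200 nM to 10000 nM.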

Compound 4, inhibition constant: 1900 nM
The estimate for compound 4 lay 1.8-fold (0.27 log units) above the measured number, and the stated range covers the measured number.
By their numbers in this assay, from the lowest: compound 3; then compound 2; then compound 4; then compound 1.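

Moving from 4-cyano-1H-pyrazol-1-yl to 4-methyl-1H-pyrazol-1-yl gives the first single-place comparison in this assay, with a 2.2-fold lower number from compound 1 to compound 4 (0.33 log units; beyond the scatter), a modest step. The nitrile on this aromatic carbon is therefore not required for measurable displacement of the labelled ligand, and methyl gives a slightly stronger inhibitor here. Nothing available explains this step. The compounds shown leave open how a chlorine atom, an ethyl group or an amine on this carbon would compare, and whether the step would carry over to the cores of compound 2 and compound 3.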